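Ester variation on a furanyl dihydropyrimidinone core

The source may hold more compounds than are shown below. What is called first, only, known or untested is meant among the compounds shown, and "the series" means these compounds.

Compound 2 `CCC(C)OC(=O)C1=C(C)NC(=O)NC1c1ccoc1` is one of the two compounds measured in an assay on membranes from HeLa cells for displacement of a labelled ligand from adenosine receptor A3 (Homo sapiens), read by scintillation counting, with a stated time of 180 min, tested at 1 uM (on this read-out higher numbers stand for more inhibition at the one concentration tested (going by the name of the read-out) and lower numbers for less inhibition), where compound 2 gives 11%. Within the data shown here, its only measured neighbour is compound 1 `CC1=C(C(=O)OC(C)(C)C)C(c2ccoc2)NC(=O)N1`, which differs by tert-butyl instead of sec-butyl on an oxygen next to a carbonyl group; in this assay compound 1 gives 2%. Among the measured compounds shown here, the one measured step, a number 9 percentage points higher from compound 1 to compound 2 (within the scatter), is therefore small, and nothing beyond the scatter has yet been seen at this position of the shared core.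

Compound 3 `CC1=C(C(=O)OCC2CCC2)C(c2ccoc2)NC(=O)N1` continues along the same ester position. Its difference from compound 2 is cyclobutylmethyl in place of sec-butyl on an oxygen next to a carbonyl group. For the measured compounds named here, since the only step that bears on the ester group, a number 9 percentage points higher from compound 1 to compound 2 (within the scatter), stayed within the scatter, the change from sec-butyl to cyclobutylmethyl is expected to move the number in this assay by no more than the scatter, with no clear direction; the expected step is a number 1 percentage points lower from compound 2 to compound 3 (within the scatter). For compound 3 the estimated value in this assay is 10%, within a range from 0% to 25%.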

Compound 3, a percentage reported as inhibition, at one concentration (the size of the read-out at that concentration, not a potency): 2%
For compound 3 the middle estimate is 8 percentage points above the measured one; the range from low to high includes it.
By their numbers in this assay, from the lowest: compounds 1, 3 and 2 (each within the scatter of the next).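

Cyclobutylmethyl brings the first ring into the ester group on an oxygen next to a carbonyl group, and this does not separate compound 3 from the two open-chain esters in this assay. Replacing sec-butyl with cyclobutylmethyl gives a number 9 percentage points lower from compound 2 to compound 3 (within the scatter), while replacing tert-butyl with cyclobutylmethyl gives no change at the digits printed from compound 1 to compound 3 (within the scatter), so all three compounds stand within the scatter of one another and none can be ranked above another. The data available offer no independent measurement that could account for these numbers.

As far as these compounds go, it remains open whether any ester at this position can move the number in this assay beyond the scatter, for example a longer chain, a benzyl group or a chain carrying an amine or a carboxylic acid. The compounds shown also leave open whether changes elsewhere on the shared core would matter more than the ester group, as all three differ only on that oxygen.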